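Replacing the Hydroxy Group of Compound 1

The source may report more compounds than this note shows. Statements on the series, on what has been measured and on what is new or still open speak of the compounds shown alone.

In an ADME assay on MDBK cells (Bos taurus) for cytotoxicity, read by MTT assay, with a stated time of 96 h (a lower number here means that less compound is tolerated, a higher number that more compound is tolerated), compound 1 `Oc1ccc(-c2nc3cc(C(F)(F)F)ccc3[nH]2)cc1` gives 51000 nM. Compound 3 `O=[N+]([O-])c1ccc(-c2nc3cc(C(F)(F)F)ccc3n2C2CCCCC2)cc1` gives 68000 nM, and these two numbers lie within the usual scatter of each other. Compound 2 `COc1ccc(-c2nc3cc([N+](=O)[O-])ccc3[nH]2)c(OC)c1OC` reaches only a limit of the assay, > 100000 nM. So compound 1 has no measured number clearly under it or clearly over it.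

Compound 4 `O=C(O)CCC(=O)Nc1ccc(-c2nc3cc(C(F)(F)F)ccc3[nH]2)cc1` keeps the core of compound 1 but carries ((2-carboxyethyl)carbonyl)amino in place of hydroxy on an aromatic carbon, para to a large group (((2-carboxyethyl)carbonyl)amino in place of hydroxy on an aromatic carbon). Among the compounds with values here, no pair of measured compounds differs in one place only, so no measured step shows what such an exchange does in this assay. The expectation therefore rests on how close compound 3 at 68000 nM stands to compound 1 at 51000 nM. The expected change is small and stays within the scatter, with a 1.5-fold higher number from compound 1 to compound 4 (0.17 log units; within the scatter) as the estimated step. For compound 4 the estimated value is 75000 nM, with an expected range from 35000 nM to 100000 nM.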

Compound 4, half-maximal cytotoxic concentration: > 100000 nM
Compound 4 was reported as a limit; the forecaster's own chance of this, stated with the estimate: 35%; middle value at least 1.3-fold (0.12 log units) from the limit.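

Compound 4 gives > 100000 nM in this assay, which is a limit of the assay and not a number. Within the data shown here, this provides the first measured step at this position, on an aromatic carbon para to a large group: ((2-carboxyethyl)carbonyl)amino in place of hydroxy gives an at least 1.9-fold higher number from compound 1 to compound 4 (0.29 log units; that floor lies within the scatter), so exchanging a single heavy atom for a chain of 8 heavy atoms brought no lower number here. The true size of the step cannot be read, and the limit is not unique to compound 4: the limit of > 100000 nM in this assay, at which 2 of the 4 values shown sit.

From the compounds shown here alone, whether any real shift belongs to the whole chain or only to its carboxylic acid end remains open. A simple amine or a short acetyl amide on the same carbon would help separate the two.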